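Triazole to carbamoyl on the branched chain of compound 2

The source may report more compounds than this note shows. Statements on the series, on what has been measured and on what is new or still open speak of the compounds shown alone.

Measured compounds:
- compound 1 `CCn1ncc2c(F)cc(-c3ccc(C(CC)(CC)c4nnc[nH]4)c(=O)[nH]3)cc21`: 17 nM
- compound 2 `CC(C)C(Cc1nnc[nH]1)c1ccc(-c2ccc3cccc(F)c3c2)[nH]c1=O`: 10 nM
- compound 3 `CCn1ncc2c(F)cc(-c3ccc(C(CC)(CC)c4nnc(C)[nH]4)c(=O)[nH]3)cc21`: 34 nM

The read-out throughout is an assay on CHO cells for displacement of a labelled ligand from prostaglandin E2 receptor EP3 subtype (Homo sapiens), read by radioligand binding; a higher number here means a weaker inhibitor, a lower number a stronger inhibitor. Among the three numbers, compound 2 gives the lowest; compound 1 sits within the scatter of it, so the two cannot be ranked, while compound 3 lies beyond the scatter. Among the compounds with values here, the only step between measured compounds is a 2.0-fold higher number from compound 1 to compound 3 (0.30 log units; within the scatter), a methyl in place of hydrogen on an aromatic carbon of the retained triazole; it bears on compound 4 only in that it touches the same ring, and it reads as no change beyond the scatter.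

Compound 4 `CC(C)C(CC(N)=O)c1ccc(-c2ccc3cccc(F)c3c2)[nH]c1=O` differs from compound 2 by carbamoyl in place of 4H-1,2,4-triazol-3-yl on a saturated chain carbon, two bonds along the chain from an aromatic carbon. Within the data shown here, no measured pair shows a carbamoyl in place of the triazole, so there is no direct precedent; the step of a 2.0-fold higher number from compound 1 to compound 3 (0.30 log units; within the scatter) says only that a small edit on the triazole is tolerated, not what its removal costs. Given that the entering group carries one acceptor fewer and no ring, the step of a 3.5-fold higher number from compound 2 to compound 4 (0.54 log units; beyond the scatter) is expected to be a moderate loss, though a flat result cannot be excluded. Compound 4 is estimated at 35 nM, with a range from 10 nM to 120 nM.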

Compound 4, inhibition constant: 5 nM
Compound 4: the middle estimate sits 7.0-fold (0.85 log units) above what was measured; the whole stated range lies above it.
By their numbers in this assay, from the lowest: compounds 4, 2, 1 and 3 (each within the scatter of the next, the first and the last beyond it).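

In this assay, carbamoyl in place of 4H-1,2,4-triazol-3-yl on the saturated chain carbon gives a 2.0-fold lower number from compound 2 to compound 4 (0.30 log units; within the scatter), so the two compounds cannot be ranked. The earlier compounds shown here showed only a methyl edit on a retained triazole, whereas this pair shows that the whole five-membered aromatic ring can leave this position, with an open-chain carbamoyl entering, without a step beyond the scatter. Nothing available on these compounds accounts for this result.

From the compounds shown here alone, whether a carboxylic acid, a nitrile or an N-methyl carboxamide would read the same at this position remains open. Also open, going by these compounds, is whether carbamoyl would hold up on the core of compound 1, where the triazole sits on a carbon bearing two ethyl groups rather than at the end of a methylene link.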